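A 4-fluoro-1H-indol-3-yl swap at the assay limit

A few compounds are considered here, and "the series" means these few. Any claim that something is new, unique, unknown or untested is made for them only; others in the source may bear on it.

Compound 1 `O=C(COc1ccc(CN2CC=C(c3c[nH]c4ccc(F)cc34)CC2)cc1)NO` gives 1110 nM
Compound 2 `O=C(COc1ccc(C(=O)NC2CC=C(c3c[nH]c4cccc(F)c34)CC2)cc1)NO` gives > 5000 nM as a limit
Compound 3 `Cc1[nH]c2ccccc2c1C1=CCN(C(=O)c2ccc(OCC(=O)NO)cc2)CC1` gives > 5000 nM as a limit

In a functional assay on SW480 cells (Homo sapiens) for antiproliferative activity, with a stated time of 72 h (a higher number here means a weaker inhibitor, a lower number a stronger inhibitor), compound 3 gives > 5000 nM as a limit of the assay and not as a number. This is the limit of > 5000 nM in this assay, at which 2 of the 3 values shown sit, and so compound 3 has no exact place on the scale. Only compound 1 has a measured number.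

Compound 4 `O=C(COc1ccc(C(=O)N2CC=C(c3c[nH]c4cccc(F)c34)CC2)cc1)NO` has yet to be measured in this assay and differs from compound 3 in a single place. It has 4-fluoro-1H-indol-3-yl in place of 2-methyl-1H-indol-3-yl on a double-bonded ring carbon. For the measured compounds named here, no measured pair shows this change on its own, so what follows is an expectation. It leans on compound 2, which carries the same 4-fluoro-1H-indol-3-yl group and gives > 5000 nM as a limit. Only a small move towards stronger inhibition, or none beyond the scatter, is expected. The estimated step is an at least 1.1-fold lower number from compound 3 to compound 4 (0.04 log units; that floor lies within the scatter) and it remains uncertain while compound 3 has only a limit. For compound 4 the expected value is 4500 nM with an estimated range from 2000 nM to 10000 nM and a report of only a limit would be no surprise.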

Compound 4, half-maximal inhibitory concentration: 1490 nM
The estimate for compound 4 lay 3.0-fold (0.48 log units) above the measured number; measured number outside the range, below it.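

For the compounds shown here, at this place, on a double-bonded ring carbon of a six-membered non-aromatic ring with 1 nitrogen, putting 4-fluoro-1H-indol-3-yl in place of 2-methyl-1H-indol-3-yl gives in this assay an at least 3.3-fold lower number from compound 3 to compound 4 (0.52 log units; beyond the scatter), the first step that can be read at all. Going by these compounds alone, no two of the earlier compounds differed in one place, so only this pair shows that a change in the indolyl group alone, with the rest of the structure held fixed, can take a compound from the limit of the assay to a measured number. Compound 3 holds a limit and not a number, so this step is a floor and its full size remains unknown: the limit of > 5000 nM in this assay, at which 2 of the 4 values shown sit.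

The change removes a methyl group and adds a fluorine in a single exchange, and the compounds shown do not separate the two; the unsubstituted 1H-indol-3-yl group would be needed to tell them apart. From the compounds shown here alone, whether a chlorine or a methoxy group in place of the fluorine would give a similar number also stays open.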